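Fluorophenyl sulfonyl series: positional change from compound 2

The source may hold more compounds than are shown below. What is called first, only, known or untested is meant among the compounds shown, and "the series" means these compounds.

Measured so far in a functional assay on HeLa cells for agonist activity at 5-hydroxytryptamine receptor 6 (Homo sapiens), read by immunoassay; a higher number here means a larger maximal response, a lower number a smaller maximal response:
compound 1 `Cc1c(S(=O)(=O)c2ccccc2)c2cccnc2n1CCN` — 85%
compound 2 `NCCn1cc(S(=O)(=O)c2cccc(F)c2)c2cccnc21` — 100%
compound 3 `O=S(=O)(c1cccc(F)c1)c1cn(CCN2CCCC2)c2ncccc12` — "not determined" (no result reported)

Compound 2 stands highest of the two numbers in this assay; compound 1 lies lower by a gap beyond the usual scatter, and compound 3 gives no number at all. For the measured compounds named here, no single-point step between measured compounds is available, so the next move rests on compound 2 alone.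

Compound 4 `NCCn1cc(S(=O)(=O)c2ccc(F)cc2)c2cccnc21` differs from compound 2 as follows: 4-fluorophenyl in place of 3-fluorophenyl on a sulfonyl sulfur. Going by the values given here, with no comparable step in the data, the expectation for this change in this assay is a step of no size beyond the scatter, if anything slightly downward. Compound 4 is therefore estimated at 92% (72% to 108%), an expected step of a number 8 percentage points lower from compound 2 to compound 4 (within the scatter).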

Compound 4, largest response reached (Emax), in percent of the reference or control that the assay uses: 100%
Compound 4: the middle estimate sits 8 percentage points below what was measured; measured number inside the range.
By their numbers in this assay, from the lowest: compound 1; then compounds 2 and 4 (each within the scatter of the next).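

In this assay, for the compounds shown here, 4-fluorophenyl in place of 3-fluorophenyl on a sulfonyl sulfur gives no change at the digits printed from compound 2 to compound 4 (within the scatter), the only single-place step so far. The maximal response at this position is therefore insensitive to this change of fluorine placement on the phenyl ring, at least for this pair. No data on hand explain this result. Open, from the compounds shown here alone, is whether a chlorophenyl or pyridyl group on the sulfonyl sulfur holds the response. Going by these compounds, the effect of the pyrrolidine on the chain also remains open, with compound 3 giving no number.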